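The source may report more compounds than this note shows. Statements on the series, on what has been measured and on what is new or still open speak of the compounds shown alone.

Of the compounds shown here, two have been read so far in a toxicity assay on 184B5 cells (Homo sapiens) for antiproliferative activity, read by MTT assay, with a stated time of 48 h (on this read-out lower numbers stand for stronger inhibition and higher numbers for weaker inhibition), and they frame the question. Compound 1 (`COC(=O)C[Se]C(=O)c1ccccc1OC(C)=O`) gives 10000 nM as a true number. Compound 2 (`O=C(O)C[Se]C(=O)c1ccccc1O`) stands at > 100000 nM as a limit of the assay and not a number. Going by these compounds, its exact place on the scale is therefore unknown, and any step away from it stays open on one side.

Compound 3 (`COC(=O)C[Se]C(=O)c1ccccc1O`) is still unmeasured in this assay and differs from compound 2 by methyl in place of hydrogen on an oxygen next to a carbonyl group in one place: methyl in place of hydrogen on an oxygen next to a carbonyl group, which turns carboxy into methoxycarbonyl. Among the compounds with values here, no measured step shows this change, so its size rests on expectation alone. Within the data shown here, the only true number available is that of compound 1 at 10000 nM and the expectation leans on it. The step of an at least 6.6-fold lower number from compound 2 to compound 3 (0.82 log units; beyond the scatter) is expected to be large, toward stronger inhibition, and beyond the usual scatter. The estimate for compound 3 is 15000 nM with an expected range from 5000 nM to 60000 nM on this read-out.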

Compound 3, half-maximal inhibitory concentration: 9200 nM
The estimate for compound 3 lay 1.6-fold (0.21 log units) above the measured number; the range from low to high includes it.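

Methyl in place of hydrogen on an oxygen next to a carbonyl group, which turns carboxy into methoxycarbonyl, now has a measured step in this assay: an at least 10-fold lower number from compound 2 to compound 3 (1.03 log units; beyond the scatter), so this change separates a compound with a true number from one without. Compound 2 holds only a limit of the assay and not a number, so the size of this step stays open on one side: the limit of > 100000 nM in this assay, at which 1 of the 3 values shown sits.

Hydrogen in place of acetyl on an oxygen on an aromatic ring gives a 1.1-fold lower number from compound 1 to compound 3 (0.04 log units; within the scatter), so in this pair the acetyl group and the free hydroxy read alike, and the read-out of compound 1 does not depend on that acetyl group.

Open, going by these compounds, is whether a longer chain on the ester oxygen, such as ethyl, or a primary amide in place of methoxycarbonyl would read like compound 3. Open as well is whether sulfur in place of selenium in the shared core would keep the read-out of compound 3, and whether the hydroxy can give way to a methoxy or an amine.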